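Shifting the aryl group on the pyrazole-amine hydroxamate core

The compounds below may be only part of what the source reports. "The series", "measured", "known", "first", "only" and "open" are said of these compounds alone.

Measured compounds:
compound 1 `CS(=O)(=O)c1ccc(-n2ccc3cnc(Nc4cnn(CCCCCCC(=O)NO)c4)nc32)cc1` — 5.9 nM
compound 2 `CS(=O)(=O)c1ccc(-n2ccc3cnc(Nc4cnn(CCCCCC(=O)NO)c4)nc32)cc1` — 10.8 nM
compound 3 `O=C(CCCCCn1cc(Nc2ncc3ccn(Cc4ccccc4Cl)c3n2)cn1)NO` — 45 nM

In an assay on isolated protein for inhibition of protein deacetylase HDAC6 (Homo sapiens), with a stated time of 60 min (on this read-out lower numbers stand for stronger inhibition and higher numbers for weaker inhibition), compound 1 gives the lowest number of the three; compound 2 lies within the scatter of it, as a 1.8-fold higher number from compound 1 to compound 2 (0.26 log units; within the scatter) shows, while compound 3 stands beyond it. Compound 4 `O=C(CCCCCCn1cc(Nc2ncc3ccn(Cc4cccc(F)c4)c3n2)cn1)NO` is not yet measured. It differs from compound 1 in one place: 3-fluorobenzyl in place of 4-(methylsulfonyl)phenyl on an aromatic nitrogen. Among the compounds with values here, the step that bears on this change is the one from compound 2 to compound 3, in which a 2-chlorobenzyl took the same place on the same aromatic nitrogen and gave a 4.2-fold higher number from compound 2 to compound 3 (0.62 log units; beyond the scatter). The chain length of compound 4 matches that of compound 1, so no chain effect enters. Compound 4 is therefore expected to give a modestly higher number than compound 1, about a 4.2-fold higher number from compound 1 to compound 4 (0.63 log units; beyond the scatter) in this assay. Compound 4 is estimated at 25 nM, with a range of 10 nM to 60 nM.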

Compound 4, half-maximal inhibitory concentration: 14.7 nM
Estimate against measurement, compound 4: 1.7-fold (0.23 log units) above; the range from low to high includes it.
By their numbers in this assay, from the lowest: compounds 1, 2 and 4 (each within the scatter of the next, the first and the last beyond it); then compound 3.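

On the chain of compound 1, the 3-fluorobenzyl also costs something in this assay, with a 2.5-fold higher number from compound 1 to compound 4 (0.40 log units; beyond the scatter). Together with the earlier step to compound 3, this shows that a benzyl group in place of 4-(methylsulfonyl)phenyl on this aromatic nitrogen raised the number beyond the scatter in both of the two pairs, on two chain lengths and with two different halogens. The 4-(methylsulfonyl)phenyl, with its sulfur and hydrogen-bond acceptors, can thus be replaced by a group with neither while compound 4 stays within the scatter of compound 2, and nothing available here gives a reason for the step.

Plain benzyl on the same chain would be needed to separate the fluorine from the benzyl itself. From the compounds shown here alone, whether 4-fluorobenzyl or an unsubstituted phenyl would behave alike also remains open.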